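A few compounds are considered here, and "the series" means these few. Any claim that something is new, unique, unknown or untested is made for them only; others in the source may bear on it.

Measured compounds and their values:
compound 1 `Nc1nn(CC(=O)NCCO)c2nc(-c3ccccc3)cc(C(F)(F)F)c12` — 69500 nM
compound 2 `Nc1nn(CC(=O)NCc2ccco2)c2nc(-c3ccccc3)cc(C(F)(F)F)c12` — 7100 nM
compound 3 `CN1CCN(C(=O)Cn2nc(N)c3c(C(F)(F)F)cc(-c4ccccc4)nc32)CC1` — 17700 nM

In a functional assay on HeLa cells (Homo sapiens) for cytotoxicity, read by MTT assay, with a stated time of 24 h (a higher number here means a weaker inhibitor, a lower number a stronger inhibitor), compound 2 gives the lowest of the three numbers; compound 3 sits nearest, and compound 1 furthest, with both gaps beyond the scatter. Compound 4 `CC(NC(=O)Cn1nc(N)c2c(C(F)(F)F)cc(-c3ccccc3)nc21)C(=O)O` is not yet measured. It differs from compound 2 in one place: 1-carboxyethyl in place of (furan-2-yl)methyl on an amide-type nitrogen.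

Among the measured compounds shown here, two measured steps bear on this change. The step of a 9.8-fold lower number from compound 1 to compound 2 (0.99 log units; beyond the scatter) shows that bringing in furan-2-yl on the saturated chain carbon bound to the amide-type nitrogen, in place of hydroxymethyl, lowered the number markedly. The step of a 2.5-fold higher number from compound 2 to compound 3 (0.40 log units; beyond the scatter) shows that exchanging the ((furan-2-yl)methyl)amino group for 4-methylpiperazin-1-yl raised it modestly. In both steps the compound carrying the furan-2-yl ring gives the lower number, so removing it in compound 4 is expected to raise the number in this assay, beyond the scatter, plausibly toward the value of compound 1, which also lacks the ring.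

Compound 4 is therefore estimated at 40000 nM, with a range from 12000 nM to 110000 nM, an expected step of a 5.6-fold higher number from compound 2 to compound 4 (0.75 log units; beyond the scatter).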

Compound 4, half-maximal inhibitory concentration: 20100 nM
For compound 4 the middle estimate is 2.0-fold (0.30 log units) above the measured one; measured number inside the range.
By their numbers in this assay, from the lowest: compound 2; then compounds 3 and 4 (each within the scatter of the next); then compound 1.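

In this assay, replacing (furan-2-yl)methyl with 1-carboxyethyl on the amide-type nitrogen costs something, with a 2.8-fold higher number from compound 2 to compound 4 (0.45 log units; beyond the scatter), and compound 2 keeps the lowest number of the four. Losing the ring does not by itself return the number to the level of compound 1, however: two ring-free groups on the same nitrogen give clearly different numbers, with a 3.5-fold lower number from compound 1 to compound 4 (0.54 log units; beyond the scatter), so the choice of ring-free group matters here as well. The (1-carboxyethyl)amino group also stands level with the 4-methylpiperazin-1-yl group on the carbonyl carbon, with a 1.1-fold higher number from compound 3 to compound 4 (0.06 log units; within the scatter), which shows that two very different groups can reach the same range in this assay.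

Nothing available accounts for any of these differences. As far as these compounds go, it also remains open whether a methyl ester or an amine in place of the carboxylic acid, a longer chain, or a benzyl group in place of (furan-2-yl)methyl would fall nearer compound 2 or compound 1.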